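The source may report more compounds than this note shows. Statements on the series, on what has been measured and on what is new or still open speak of the compounds shown alone.

The measured compounds:
compound 1 `Cc1ccc2cc(-c3ccc(Br)nn3)c(=O)oc2c1` gives 750 nM in an assay on cells for inhibition of Amine oxidase [flavin-containing] B (Homo sapiens), read by fluorescence and Amplex Red, with a stated time of 15 min; on this read-out higher numbers stand for weaker inhibition and lower numbers for stronger inhibition;
compound 2 `Cc1ccc2cc(-c3ccc(Cl)nn3)c(=O)oc2c1` gives 2510 nM;
compound 3 `COc1ccc2cc(-c3ccc(Cl)nn3)c(=O)oc2c1` gives 19200 nM.

Compound 2 holds the second highest of the three numbers in this assay. Its nearest neighbour is compound 1, reached by the step of a 3.3-fold higher number from compound 1 to compound 2 (0.52 log units; beyond the scatter); its furthest is compound 3, reached by the step of a 7.6-fold higher number from compound 2 to compound 3 (0.88 log units; beyond the scatter).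

Compound 4 `COc1ccc(-c2cc3ccc(C)cc3oc2=O)nn1` differs from compound 2 in one place: methoxy in place of chloro on an aromatic carbon. Going by the values given here, no measured step makes exactly this exchange. Among the compounds with values here, two steps bear on it indirectly: a 3.3-fold higher number from compound 1 to compound 2 (0.52 log units; beyond the scatter), which swapped one halogen for another at the same carbon, and a 7.6-fold higher number from compound 2 to compound 3 (0.88 log units; beyond the scatter), which brought in a methoxy in place of a methyl on the shared core. Both pushed the number up, so a rise beyond the scatter is expected here as well, with the size uncertain. Compound 4 is therefore estimated at 6500 nM, within a range of 2000 nM to 25000 nM. That estimate corresponds to an expected step of a 2.6-fold higher number from compound 2 to compound 4 (0.41 log units; beyond the scatter).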

Compound 4, half-maximal inhibitory concentration: 13500 nM
Compound 4: middle estimate off by 2.1-fold (0.32 log units), on the low side; the measured number falls inside the stated range.
By their numbers in this assay, from the lowest: compound 1; then compound 2; then compounds 4 and 3 (each within the scatter of the next).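

With the methyl kept on the shared core, the carbon next to the ring nitrogen now carries three different groups, and in this assay methoxy in place of chloro gives a 5.4-fold higher number from compound 2 to compound 4 (0.73 log units; beyond the scatter) with the rise beyond the scatter. The position therefore responds not only to an exchange of one halogen for another but also to a group that is no halogen, and measured against bromo the same methoxy gives an 18-fold higher number from compound 1 to compound 4 (1.26 log units; beyond the scatter) as the largest step seen at this carbon. The numbers rise in the order bromo, chloro, methoxy across these three compounds, with none going against it, but no measurement given here accounts for that order.

On these data alone, what an amine, a fluoro or iodo atom, or a longer chain such as ethoxy would do at this carbon remains open. Also open, as far as these compounds go, is whether a methyl on the core is needed for the order of these three groups to hold.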